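The compounds below may be only part of what the source reports. "The series", "measured", "known", "first", "only" and "open" are said of these compounds alone.

Measured compounds in the series:

Compound 1, `CC(C)=CCC/C(=C/CC/C(C)=C/CC/C(C)=C/CC1=CC(=O)C(C)=CC1=O)CO` — > 48800 nM
Compound 2, `CC(=O)OC/C(=C\CC/C(C)=C/CC/C(C)=C/CC1=CC(=O)C(C)=CC1=O)CCC=C(C)C` — 38100 nM
Compound 3, `CC(C)=CCC/C(C)=C/CC/C(C)=C/CC[C@](C)(O)/C=C\c1cc(O)c(C)cc1O` — > 48500 nM

In a functional assay on HepG2 cells (Homo sapiens) for cytotoxicity, read by MTT assay, with a stated time of 6 days (a lower number here means a stronger inhibitor, a higher number a weaker inhibitor), compound 1 gives > 48800 nM, which is a limit of the assay rather than a number. Compound 2 gives 38100 nM. Going by the values given here, the step of an at least 1.2-fold lower number from compound 1 to compound 2 (0.10 log units; that floor lies within the scatter) is the only measured step in the set, and its floor lies within the scatter. Compound 3 gives > 48500 nM, again a limit of the assay, so compound 3 stands at the weak end of the numbers shown, at the limit of > 48500 nM in this assay, at which 1 of the 3 values shown sits; a second value in the set is also a limit, (the limit of > 48800 nM in this assay, at which 1 of the 3 values shown sits).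

Compound 4, `CC(C)=CCC/C(C)=C/[C@@H](O)C/C(C)=C/CC[C@](C)(O)/C=C\c1cc(O)c(C)cc1O`, differs from compound 3 by hydroxy in place of hydrogen on a saturated chain carbon bound to a double-bonded chain carbon and a saturated chain carbon. No measured step touches a change of this kind: the one step shown concerns an acetyl on an oxygen and is within the scatter. Nothing in the data therefore points to a step beyond the scatter in this assay in either direction, and compound 4 is expected to sit where compound 3 sits.

For compound 4 the estimate in this assay is 50000 nM, with a range of 20000 nM to 150000 nM. The step that the limit leaves unreadable from compound 3 to compound 4 is thus expected to lie within the scatter, with a fair chance that only a limit is reported.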

Compound 4, half-maximal inhibitory concentration: 44400 nM
Compound 4: middle estimate off by 1.1-fold (0.05 log units), on the high side, and the stated range covers the measured number.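

In this assay, going by these compounds alone, hydroxy in place of hydrogen on a saturated chain carbon bound to a double-bonded chain carbon and a saturated chain carbon gives the only reading at this position: an at least 1.0-fold lower number from compound 3 to compound 4 (0.03 log units; that floor lies within the scatter). Compound 4 gives a number, 44400 nM. This change yields no step shown to lie beyond the scatter, while a true step larger than the floor remains possible. Compound 3 stands only at a limit of the assay, so the step has a floor and no exact size: the limit of > 48500 nM in this assay, at which 1 of the 4 values shown sits.

On these data alone, whether a methoxy or an amine on this same carbon would give a step beyond the scatter stays open. Also open, as far as these compounds go, is whether the same hydroxy would change the reading on the core of compound 1.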